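Chloro for methyl on the aryl of the amine core

The source may report more compounds than this note shows. Statements on the series, on what has been measured and on what is new or still open speak of the compounds shown alone.

Measured so far in a functional assay on NIH3T3 cells for agonist activity at Urotensin-2 receptor (Homo sapiens), with a stated time of 5 days; a lower number here means that less compound is needed, a higher number that more compound is needed for the effect:
compound 1 `COc1ccc(/C=C/C(=O)NC(CCN(C)C)c2ccc(Cl)cc2)cc1` gives 513 nM
compound 2 `CN(C)CCC(NC(=O)CCc1ccccc1)c1ccc(Cl)cc1` gives 1660 nM
compound 3 `Cc1ccc(C(CCN(C)C)NC(=O)/C=C/c2ccccc2)cc1` gives 1550 nM

Compound 3 has the second highest number of the three. Going by the values given here, its nearest neighbour is compound 2, whose number lies within the scatter of the one for compound 3, so no order between them can be stated. Compound 1 sits furthest away with a number beyond the scatter lower than that of compound 3.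

The next compound, compound 4 `CN(C)CCC(NC(=O)/C=C/c1ccccc1)c1ccc(Cl)cc1`, is not yet measured in this assay . It differs from compound 3 in one place: chloro in place of methyl on an aromatic carbon. Among the compounds with values here, both compound 1 and compound 2 already carry the chlorophenyl that enters here, but neither is a single-change partner of compound 4, so no direct step for this exchange exists among the measured compounds; the values of compound 1 and compound 2 only bracket the range in which chlorophenyl analogues have fallen.

For compound 4 a small step toward a lower number is expected, a 1.6-fold lower number from compound 3 to compound 4 (0.19 log units; within the scatter), most likely within the scatter. The estimate for compound 4 in this assay is 1000 nM, expected between 350 nM and 2800 nM.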

Compound 4, half-maximal effective concentration: 427 nM
Compound 4: the middle estimate sits 2.3-fold (0.37 log units) above what was measured; the measured number falls inside the stated range.
By their numbers in this assay, from the lowest: compounds 4 and 1 (each within the scatter of the next); then compounds 3 and 2 (each within the scatter of the next).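

In this assay, going by these compounds alone, exchanging 4-methylphenyl for 4-chlorophenyl gives a 3.6-fold lower number from compound 3 to compound 4 (0.56 log units; beyond the scatter), the first single-change reading at this position, and it shows that the group on this aromatic carbon affects the number. With the chlorophenyl kept, 2-phenylethenyl in place of phenethyl on the carbonyl carbon gives a 3.9-fold lower number from compound 2 to compound 4 (0.59 log units; beyond the scatter), while hydrogen in place of methoxy on the other aromatic ring gives a 1.2-fold lower number from compound 1 to compound 4 (0.08 log units; within the scatter), so these two compounds cannot be told apart. No data given here explain any of these steps.

On these data alone, whether the chloro result extends to fluoro, bromo or trifluoromethyl at this position remains open. Also open, as far as these compounds go, is whether the exchange holds when the dimethylamino group gives way to a pyrrolidine or a primary amine, or when the chain carrying it is longer.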